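The compounds below may be only part of what the source reports. "The series", "measured", "known", "first", "only" and "open" are said of these compounds alone.

The compounds share one core, seen in compound 1 `CCN(Cc1ccccc1)C(=O)C1CCN(S(=O)(=O)c2ccccn2)CC1`, compound 2 `CCN(C(=O)C1CCN(S(=O)(=O)c2ccc3occc3c2)CC1)[C@H](C)c1ccccc1` and compound 3 `CCN(Cc1cccc(F)c1)C(=O)C1CCN(S(=O)(=O)c2ccc3cn[nH]c3c2)CC1`. In a functional assay on CHO cells for positive allosteric modulation of muscarinic acetylcholine receptor M5 (Homo sapiens), read by calcium flux (on this read-out lower numbers stand for smaller maximal responses and higher numbers for larger maximal responses), compound 1 is recorded as "not determined" (no result reported), so no number is available for it. In this assay compound 2 reaches 80%, and compound 3 reaches 89%; these two numbers lie within the usual scatter of each other, so neither can be set above the other. Compound 4 `CCN(Cc1ccccc1Cl)C(=O)C1CCN(S(=O)(=O)c2ccc3cn[nH]c3c2)CC1` has not yet been measured. It differs from compound 3 in one place: 2-chlorophenyl in place of 3-fluorophenyl on a saturated chain carbon bound to an amide-type nitrogen. Among the measured compounds shown here, no measured pair shows this kind of change, so nothing is known of its effect here. A step from compound 3 to compound 4 of a number 4 percentage points lower from compound 3 to compound 4 (within the scatter) is expected, nothing beyond the scatter. In this assay compound 4 is estimated at 85%, between 65% and 100%.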

Compound 4, largest response reached (reported as percent of maximum), in percent of the reference or control that the assay uses: 93%
Beside the measured number, compound 4's estimate is 8 percentage points below it; the measured number falls inside the stated range.
By their numbers in this assay, from the lowest: compounds 2, 3 and 4 (each within the scatter of the next, the first and the last beyond it).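

Among the compounds shown here, this is the first pair in the set that differs in only one place. In this assay, 2-chlorophenyl in place of 3-fluorophenyl on a saturated chain carbon bound to an amide-type nitrogen gives a number 4 percentage points higher from compound 3 to compound 4 (within the scatter), so this position tolerates this exchange of one halogen-bearing phenyl for the other. Nothing available here bears on the reason for this result. Still open, from the compounds shown here alone, is whether the maximal response would hold with a carboxylic acid or an amine on this phenyl ring. Also open, going by these compounds, is whether a longer chain in place of the benzyl carbon would hold it.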